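The compounds below may be only part of what the source reports. "The series", "measured", "known", "first", "only" and "open" are said of these compounds alone.

Measured compounds: compound 1 `O=C(CCCCC1CCSS1)Nc1ccc(OC(F)(F)F)cc1` gives 8.57% in a functional assay on HO8910 cells (Homo sapiens) for inhibition, read by MTT assay, with a stated time of 24 h, tested at 10 ug/mL; a lower number here means less inhibition of growth, a higher number more inhibition of growth at the concentration tested; compound 3 `O=C(CCCCC(S)CCS)Nc1ccc(OC(F)(F)F)cc1` gives 6.11% in this assay; compound 2 `O=C(CCCCC1CCSS1)Nc1cccc2ccccc12` is reported in this assay as "not active" (no number reported), with no number given.

Compounds 1 and 3 share a core, and compound 3 differs from compound 1 by a group of 5 heavy atoms (3 carbon, 2 sulfur; no ring) in place of a group of 5 heavy atoms (3 carbon, 2 sulfur; one five-membered non-aromatic ring with 2 hetero atoms), on a saturated chain carbon, four bonds along the chain from a carbonyl carbon. This change made a step of a number 2.5 percentage points lower from compound 1 to compound 3 (within the scatter). The difference between the core of compound 1 and the core of compound 2 is not broken down here. Compound 4 `O=C(CCCCC(S)CCS)Nc1cccc2ccccc12` is not yet measured; it differs from compound 2 by a group of 5 heavy atoms (3 carbon, 2 sulfur; no ring) in place of a group of 5 heavy atoms (3 carbon, 2 sulfur; one five-membered non-aromatic ring with 2 hetero atoms), on a saturated chain carbon, four bonds along the chain from a carbonyl carbon, the same kind of change at the same place. Since compound 2 is reported as not active, and the same change gave only a number 2.5 percentage points lower from compound 1 to compound 3 (within the scatter), compound 4 is expected to show little growth inhibition in this assay. Compound 4 is estimated at 4%, between 0% and 14%.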

Compound 4, percent growth inhibition at one concentration: "not active" (no number reported)
No number was reported for compound 4, and the estimate cannot be compared.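

Compound 2 and compound 4 are both reported as not active in this assay with no number, so no step can be read between them. The compounds shown leave open whether the 1,3-disulfanylpropyl group alters growth inhibition on the core of compound 2. No other data shown bear on this result.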